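Adding a Second Chloro to the Purine-Like Core

A few compounds are considered here, and "the series" means these few. Any claim that something is new, unique, unknown or untested is made for them only; others in the source may bear on it.

Of the compounds shown here, two have been measured in a functional assay on SF-295 cells (Homo sapiens) for cytotoxicity, read by sulforhodamine B assay, with a stated time of 48 h; on this read-out higher numbers stand for lower toxicity in this test and lower numbers for higher toxicity in this test. Compound 1 `ClCc1ccccc1Cn1cnc2c(Cl)ncnc21` gives 51300 nM in this assay. Compound 2 `ClCc1cccc(Cn2cnc3c(Cl)ncnc32)c1` gives 29500 nM in this assay; this number and that of compound 1 lie within the usual scatter of each other, so the two compounds cannot be told apart on this read-out.

Compound 3 `ClCc1cccc(Cn2cnc3c(Cl)nc(Cl)nc32)c1` has not yet been measured. It differs from compound 2 by one change: chloro in place of hydrogen on an aromatic carbon. Going by the values given here, no measured pair shows what such a change does on this core, so the expectation rests on the structural change alone and is uncertain. The added chloro is a small group, and the step from compound 2 to compound 3 is expected to be modest, a 1.5-fold lower number from compound 2 to compound 3 (0.17 log units; within the scatter), with a slight lean toward a lower number. Compound 3 is therefore estimated at 20000 nM in this assay, within a range from 7000 nM to 60000 nM.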

Compound 3, concentration lethal to 50% of the cells: 45700 nM
Estimate against measurement, compound 3: 2.3-fold (0.36 log units) below; the measured number falls inside the stated range.
By their numbers in this assay, from the lowest: compounds 2, 3 and 1 (each within the scatter of the next).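

In this assay chloro in place of hydrogen on the aromatic carbon between two ring nitrogen atoms gives a 1.5-fold higher number from compound 2 to compound 3 (0.19 log units; within the scatter) and leaves the two compounds indistinguishable on this read-out. Compounds 1 and 2 both carry hydrogen on this carbon, so they could say nothing about substitution there. This first measured step shows that this carbon can carry a chloro with no difference that this read-out can separate from the scatter of repeated measurements. No measured evidence here bears on the reason for this result.

One small group on one core cannot show how far this position tolerates change. An amine or a methoxy group on the same carbon could still give a number clearly apart from that of compound 2, and the compounds shown leave this open.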